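Swapping the Ester for a Dichlorophenyl Amide

This account rests on a few compounds, and the source may have more. Where it says the series, first, only, none or still open, it means among the compounds named here.

Compound 1 `COc1cc(/C=C/C(=O)c2cccc(NC(=O)c3ccc(Cl)c(Cl)c3)c2)ccc1O`: in a functional assay on Vero cells (Chlorocebus sabaeus) for inhibition (on this read-out lower numbers stand for stronger inhibition and higher numbers for weaker inhibition), compound 1 gives only the assay limit > 50 ug/mL.
Compound 2 `CCOC(=O)C(=O)Nc1cccc(C(=O)/C=C/c2ccc(O)c(OC)c2)c1`: in this assay compound 2 gives only the assay limit > 50 ug/mL.

Compound 2 thus stands at the limit of > 50 ug/mL in this assay, at which 2 of the 2 values shown sit, so only a limit, not a number, is known for it. Compound 3 `COc1cc(/C=C/C(=O)c2cccc(NC(=O)c3ccc(Cl)cc3Cl)c2)ccc1O` differs from compound 2 by 2,4-dichlorophenyl in place of ethoxycarbonyl on a carbonyl carbon. For the measured compounds named here, the one measured step, a step that the two limits leave unreadable from compound 1 to compound 2, runs between two limits, so its size cannot be read. With both measured neighbours at the limit, no step beyond the scatter is expected in this assay for compound 3. For compound 3 the estimated step that the limit leaves unreadable from compound 2 to compound 3 is near zero. Compound 3 is expected at 60 ug/mL, within 30 ug/mL to 200 ug/mL, most likely reported again as a limit.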

Compound 3, half-maximal inhibitory concentration: 27.2 ug/mL
Compound 3: middle estimate off by 2.2-fold (0.34 log units), on the high side; measured number outside the range, below it.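

On the carbonyl carbon whose other neighbour is the amide-type nitrogen, 2,4-dichlorophenyl is the only group among those shown to give a number rather than a limit in this assay. Against ethoxycarbonyl, it gives an at least 1.8-fold lower number from compound 2 to compound 3 (0.26 log units; that floor lies within the scatter), and against 3,4-dichlorophenyl, it gives an at least 1.8-fold lower number from compound 1 to compound 3 (0.26 log units; that floor lies within the scatter), while the step joining the two limits cannot be read. Both readable steps are only floors because one end of each sits at a limit: the limit of > 50 ug/mL in this assay, at which 2 of the 3 values shown sit.

Going by these compounds, whether the true steps exceed the scatter remains open. Also open, on these data alone, is how a plain phenyl ring or a longer chain carrying an amine would fare on this carbonyl carbon.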